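The compounds below may be only part of what the source reports. "The series", "measured", "known", "first", "only" and "open" are said of these compounds alone.

Measured in a functional assay on the whole organism (stomach) with Rattus norvegicus as the target; a higher number here means that more compound is needed for the effect, a lower number that less compound is needed:
Compound 1 `CC(=O)CCCCCC/N=C/N1CCC(C(c2ccccc2)c2ccccc2)CC1`: 10.5 mg/kg
Compound 2 `OCCCCCCCC/N=C/N1CCC(C(c2ccccc2)c2ccccc2)CC1`: 8.5 mg/kg

In this assay, compound 2 stands at 8.5 mg/kg, level with compound 1 within the usual scatter of such measurements. Among the compounds with values here, only two numbers are available, so this says little about the wider series. The next compound, compound 3 `COC(=O)CCCCCCC/N=C/N1CCC(C(c2ccccc2)c2ccccc2)CC1`, keeps the shared core and replaces the chain terminus: methoxycarbonyl in place of hydroxymethyl on a saturated chain carbon, seven bonds along the chain from a double-bonded nitrogen. In words, this is methoxycarbonyl in place of hydroxymethyl on a saturated chain carbon, seven bonds along the chain from a double-bonded nitrogen.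

Within the data shown here, one measured step bears on this change, a 1.2-fold lower number from compound 1 to compound 2 (0.09 log units; within the scatter). That step exchanged acetyl for 2-hydroxyethyl and left the number within the scatter. Among the measured compounds shown here, it is a different exchange from the one in compound 3, and no ester has been measured, so it offers only limited guidance. On this evidence, no step beyond the scatter is expected in this assay, in either direction. The expected step is a 1.2-fold higher number from compound 2 to compound 3 (0.07 log units; within the scatter). For compound 3 the estimated value is 10 mg/kg, with an expected range from 4 mg/kg to 25 mg/kg.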

Compound 3, dose for half-maximal effect: 10.1 mg/kg
Compound 3: the middle estimate sits 1.0-fold (0.00 log units) below what was measured; low and high end bracket the measured number.
By their numbers in this assay, from the lowest: compounds 2, 3 and 1 (each within the scatter of the next).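

In this assay, the result shows that an ester at this chain end leaves the number within the scatter: methoxycarbonyl in place of hydroxymethyl, on a saturated chain carbon seven bonds along the chain from a double-bonded nitrogen, gives a 1.2-fold higher number from compound 2 to compound 3 (0.07 log units; within the scatter). The group that enters carries no hydrogen-bond donor, whereas hydroxymethyl carries one, so among these compounds the presence of that donor at the chain end does not separate the numbers. The comparison with the ketone-bearing chain points the same way, since (methoxycarbonyl)methyl in place of acetyl, on a saturated chain carbon six bonds along the chain from a double-bonded nitrogen, gives a 1.0-fold lower number from compound 1 to compound 3 (0.02 log units; within the scatter), and all three compounds now lie within the scatter of one another. No measurement offered here explains this outcome.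

Whether this position can move the number at all remains open, as no step shown so far goes beyond the scatter. A carboxylic acid or an amine at the chain end, or a longer chain carrying the same ester, would test this more severely than the three termini shown here.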